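A few compounds are considered here, and "the series" means these few. Any claim that something is new, unique, unknown or untested is made for them only; others in the source may bear on it.

Working notes on a series sharing one core, followed in an assay on isolated protein for inhibition of alkaline phosphatase, tissue-nonspecific isozyme (Homo sapiens); on this read-out higher numbers stand for weaker inhibition and lower numbers for stronger inhibition. Compound 1 `CN1CCN(C(=O)c2cc(-c3ccc(Cl)cc3Cl)n[nH]2)CC1` gives 828 nM. Compound 2 `O=C(c1cc(-c2ccc(Cl)cc2Cl)n[nH]1)N1CCOCC1` gives 574 nM; the step of a 1.4-fold lower number from compound 1 to compound 2 (0.16 log units; within the scatter) stays within the scatter, so these two values are not ordered. Compound 3 `O=C(NCCCCO)c1cc(-c2ccc(Cl)cc2Cl)n[nH]1` gives 35 nM, the lowest of the three numbers, and its steps from the other two, a 24-fold lower number from compound 1 to compound 3 (1.37 log units; beyond the scatter) and a 16-fold lower number from compound 2 to compound 3 (1.21 log units; beyond the scatter), both lie beyond the scatter, so compound 3 stands apart as the strongest inhibitor of the three.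

Compound 4 `CCN(CC)C(=O)c1cc(-c2ccc(Cl)cc2Cl)n[nH]1` is not yet measured. It differs from compound 3 in one place: diethylamino in place of (4-hydroxybutyl)amino on a carbonyl carbon. Both measured steps into compound 3 bear on this change: each replaced a group lacking the amide hydrogen with one carrying it and gave a large lowering of the number, a 24-fold lower number from compound 1 to compound 3 (1.37 log units; beyond the scatter) and a 16-fold lower number from compound 2 to compound 3 (1.21 log units; beyond the scatter). Compound 4 returns to a group that lacks the amide hydrogen, so a step back upward in this assay, of a size comparable to those two, is expected, a 17-fold higher number from compound 3 to compound 4 (1.23 log units; beyond the scatter). The values of compound 1 and compound 2 mark the level to which it is expected to return. Compound 4 is therefore estimated at 600 nM, with a range from 200 nM to 2000 nM.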

Compound 4, half-maximal inhibitory concentration: 285 nM
The estimate for compound 4 lay 2.1-fold (0.32 log units) above the measured number, and the stated range covers the measured number.
By their numbers in this assay, from the lowest: compound 3; then compounds 4, 2 and 1 (each within the scatter of the next, the first and the last beyond it).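

Compound 4 carries diethylamino, which has no ring, as does (4-hydroxybutyl)amino, yet the step in this assay is an 8.1-fold higher number from compound 3 to compound 4 (0.91 log units; beyond the scatter) and so the absence of a ring on the carbonyl carbon does not by itself bring a compound to the level of compound 3. The comparison with the ring-bearing groups divides: the step (a 2.0-fold lower number from compound 2 to compound 4 (0.30 log units; within the scatter)) leaves diethylamino unordered against morpholin-4-yl, while the step (a 2.9-fold lower number from compound 1 to compound 4 (0.46 log units; beyond the scatter)) separates it from 4-methylpiperazin-1-yl. No measurement at hand gives a cause for any of these steps.

The change from compound 3 to compound 4 removes the amide hydrogen and the hydroxyl together, so the compounds shown do not tell which of the two, if either, accounts for the step. Open, therefore, is where butylamino, which keeps the amide hydrogen without the hydroxyl, and (4-hydroxybutyl)(methyl)amino, which keeps the hydroxyl without the amide hydrogen, would fall relative to compound 3 and compound 4.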